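The source may hold more compounds than are shown below. What is called first, only, known or untested is meant among the compounds shown, and "the series" means these compounds.

Compound 2 `O=C(Nc1ccc(-n2ccc3c(NC(=O)c4ccccc4)nccc32)cc1)Nc1ccc(Cl)c(C(F)(F)F)c1` stands as the weaker of the two compounds measured in a functional assay on A-375 cells (Homo sapiens) for antiproliferative activity, read by MTT assay, with a stated time of 48 h, in the presence of a further agent that is not named here; a higher number here means a weaker inhibitor, a lower number a stronger inhibitor: compound 2 gives 2400 nM, whereas compound 1 `O=C(Nc1ccc(-n2ccc3c(NC(=O)c4ccccc4)nccc32)cc1)Nc1ccc(Cl)c(Cl)c1` gives 200 nM. Among the measured compounds shown here, the single measured step, a 12-fold higher number from compound 1 to compound 2 (1.08 log units; beyond the scatter), concerns trifluoromethyl in place of chloro on an aromatic carbon, and it is large. Compound 3 `O=C(Nc1ccc(-n2ccc3c(NC(=O)c4ccccc4)nccc32)cc1)c1ccc(Cl)c(C(F)(F)F)c1` keeps the trifluoromethyl of compound 2 and differs from it elsewhere: 4-chloro-3-(trifluoromethyl)phenyl in place of (4-chloro-3-(trifluoromethyl)phenyl)amino on a carbonyl carbon. None of the measured steps bears on this kind of change; the only step available involves a different part of the molecule, so neither the size nor the direction of the step in this assay can be read from the numbers shown. Compound 2, at 2400 nM, is the only anchor. The most defensible expectation is therefore a step of modest size, with a wide margin on both sides. Compound 3 is expected to give 3000 nM, within a range of 800 nM to 12000 nM. For compound 3 this means an expected step of a 1.3-fold higher number from compound 2 to compound 3 (0.10 log units; within the scatter), which may well lie within the scatter.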

Compound 3, half-maximal inhibitory concentration: 16.4 nM
Beside the measured number, compound 3's estimate is 180-fold (2.26 log units) above it, outside the stated range (below it).
By their numbers in this assay, from the lowest: compound 3; then compound 1; then compound 2.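

Within this assay, the group on the carbonyl carbon proves to be a strong determinant of the read-out: 4-chloro-3-(trifluoromethyl)phenyl in place of (4-chloro-3-(trifluoromethyl)phenyl)amino, with the same ring substituents on both sides of the change, gives a 150-fold lower number from compound 2 to compound 3 (2.17 log units; beyond the scatter), which exceeds the earlier chloro-to-trifluoromethyl step of a 12-fold higher number from compound 1 to compound 2 (1.08 log units; beyond the scatter). The trifluoromethyl group therefore does not by itself mark a weak compound here, and the change also carries the series past its earlier best, with a 12-fold lower number from compound 1 to compound 3 (1.09 log units; beyond the scatter), although that step combines the loss of the amino link with a different substitution on the ring. Nothing at hand explains why removing the amino link has so large an effect.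

The compounds shown leave open whether 3,4-dichlorophenyl attached directly to the carbonyl carbon would retain the advantage of chloro over trifluoromethyl seen with the amino link, and so whether the two changes act independently. They also leave open how a methylamino group, an oxygen atom or a methylene group would compare with the amino link or with the direct attachment at this carbonyl carbon.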